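Compound 3 after the 3-methoxybenzyl step: working notes

The source may report more compounds than this note shows. Statements on the series, on what has been measured and on what is new or still open speak of the compounds shown alone.

Values so far in an ADME assay on L02 cells (Homo sapiens) for inhibition, read by CCK-8 assay, with a stated time of 48 h; a higher number here means a weaker inhibitor of growth, a lower number a stronger inhibitor of growth
- compound 1 `Cc1ccccc1Nc1nc(Nc2ccc(N3CCN(C)CC3)cn2)ncc1Cl` gives 5980 nM
- compound 2 `COc1cccc(CNc2nc(Nc3ccc(N4CCN(C)CC4)cn3)ncc2Cl)c1` gives 16200 nM

Compound 2 holds the higher of the two numbers in this assay, so it is the weaker inhibitor of growth of this pair, and the gap to compound 1 lies beyond the scatter. Next in line is compound 3 `Cc1cccc(Nc2nc(Nc3ccc(N4CCN(C)CC4)cn3)ncc2Cl)c1`, which has 3-methylphenyl in place of 3-methoxybenzyl on a nitrogen on an aromatic ring.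

Within the data shown here, only one measured step bears on this change: a 2.7-fold higher number from compound 1 to compound 2 (0.43 log units; beyond the scatter). That step is modest and brought the 3-methoxybenzyl group in, replacing a methylphenyl group. Compound 3 goes the other way, back to a methylphenyl group, so a modest move to a lower number is expected. Among the measured compounds shown here, no measured compound carries 3-methylphenyl itself, and a single step is thin support, so the range stays wide. The expected step is a 2.3-fold lower number from compound 2 to compound 3 (0.36 log units; beyond the scatter). For compound 3 the estimated value is 7000 nM, with an expected range of 3000 nM to 15000 nM.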

Compound 3, concentration for 50% growth inhibition: 6080 nM
Estimate against measurement, compound 3: 1.2-fold (0.06 log units) above, within the range that was stated.
By their numbers in this assay, from the lowest: compounds 1 and 3 (each within the scatter of the next); then compound 2.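

In this assay, among these compounds, 3-methylphenyl in place of 3-methoxybenzyl on a nitrogen on an aromatic ring gives a 2.7-fold lower number from compound 2 to compound 3 (0.43 log units; beyond the scatter) and so shows that a methylphenyl group other than the one in compound 1 also gives a lower number than 3-methoxybenzyl at this place. Exchanging 2-methylphenyl for 3-methylphenyl at the same nitrogen gives a 1.0-fold higher number from compound 1 to compound 3 (0.01 log units; within the scatter) and leaves the two methylphenyl groups within the scatter of each other, so among these three compounds the assay separates only 3-methoxybenzyl from the two methylphenyl groups. No measured information on the cause of that separation is available for this series.

The step away from 3-methoxybenzyl changes both the methoxy group and the carbon link between the nitrogen and the ring, so the compounds shown cannot assign the gap to either feature; 3-methylbenzyl and 3-methoxyphenyl on this nitrogen would separate the two. Going by these compounds, how a ring carrying an amine or a carboxylic acid would read at this place also stays open.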